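A Ring Nitrogen Replaces the Cyclopropylamine

A few compounds are considered here, and "the series" means these few. Any claim that something is new, unique, unknown or untested is made for them only; others in the source may bear on it.

Compound 1, `CCCc1ccc(NC2=CC(=O)c3c(nc4n3[C@H]3OC[C@@H](O)[C@H]3OC4)C2=O)cc1`: 6030 nM
Compound 2, `O=C1C(NC2CC2)=CC(=O)c2c1nc1n2[C@H]2OC[C@@H](O)[C@H]2OC1`: a limit of the assay, > 16000 nM
Compound 3, `O=C1C=C(Nc2cccc(Cl)c2)C(=O)c2c1nc1n2[C@H]2OC[C@@H](O)[C@H]2OC1`: 6040 nM

In a functional assay on HeLa cells (Homo sapiens) for inhibition, read by sulforhodamine B assay (a lower number here means a stronger inhibitor, a higher number a weaker inhibitor), compound 1 gives 6030 nM and compound 3 gives 6040 nM. Compound 2 reaches only a limit of the assay, > 16000 nM. Of the three values shown, compound 2 therefore sits at the weak end, being the one that rests at the limit of > 16000 nM in this assay, at which 1 of the 3 values shown sits. Within the data shown here, the single measured step, an at least 2.6-fold higher number from compound 1 to compound 2 (0.42 log units; beyond the scatter), shows that trading the aryl group on the amine nitrogen for cyclopropyl weakened inhibition.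

Compound 4, `O=C1C(N2CCCC2)=CC(=O)c2c1nc1n2[C@H]2OC[C@@H](O)[C@H]2OC1`, differs from compound 2 by pyrrolidin-1-yl in place of cyclopropylamino on a double-bonded ring carbon. Among the measured compounds shown here, no measured step bears directly on this change: the one step known alters what hangs on the amine nitrogen, whereas here the amine itself gives way to a ring nitrogen. With compound 2 at a limit, the direction of the step cannot be read from the numbers. Compound 4 is expected to stay weak, with an estimated step that the limit leaves unreadable from compound 2 to compound 4. Compound 4 is estimated at 20000 nM, within a range of 6000 nM to 60000 nM.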

Compound 4, half-maximal inhibitory concentration: > 16000 nM
Compound 4 ended at the assay's limit (the forecaster's own chance of this, stated with the estimate: 60%); the middle value is on the limit's open side.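

Compound 2 and compound 4 both rest at a limit of this assay, so no step between them can be read: the limit of > 16000 nM in this assay, at which 2 of the 4 values shown sit.

Going by these compounds, whether pyrrolidin-1-yl or cyclopropylamino gives the stronger inhibition on the shared core stays open, and so does how far either one lies from the limit.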